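This account rests on a few compounds, and the source may have more. Where it says the series, first, only, none or still open, it means among the compounds named here.

Measured so far in a physicochemical assay for solubility, at pH 7.4; a higher number here means a more soluble compound, a lower number a less soluble compound: compound 1 `Cc1cc(C(=O)O)ccc1-c1c(N)c(C(=O)c2ccc(F)cc2F)cc[n+]1[O-]`, compound 2 `Cc1cccc(C)c1-c1c(N)c(C(=O)c2ccc(F)cc2F)cc[n+]1[O-]`, compound 3 `Cc1cc(O)ccc1-c1c(N)c(C(=O)c2ccc(F)cc2F)cc[n+]1[O-]`. In this assay compound 1 gives > 1000 ug/mL, which is a limit of the assay and not a number. Compound 2 gives 69 ug/mL. Compound 3 gives 37 ug/mL.

Compound 3 thus stands with compound 2 within the scatter of the assay, a 1.9-fold lower number from compound 2 to compound 3 (0.27 log units; within the scatter), while the step of an at least 27-fold lower number from compound 1 to compound 3 (1.43 log units; beyond the scatter) is large; compound 1 sits at the limit of > 1000 ug/mL in this assay, at which 1 of the 3 values shown sits.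

Compound 4 `Nc1c(C(=O)c2ccc(F)cc2F)cc[n+]([O-])c1-c1ccccc1Cl` differs from compound 3 by 2-chlorophenyl in place of 4-hydroxy-2-methylphenyl on an aromatic carbon. Of the measured steps, only the change of the pendant phenyl ring in a 1.9-fold lower number from compound 2 to compound 3 (0.27 log units; within the scatter) bears on it, and that step lay within the scatter. For compound 4 a value within the scatter of compound 3 is therefore expected, a 1.1-fold higher number from compound 3 to compound 4 (0.03 log units; within the scatter), with an estimate of 40 ug/mL and a range from 10 ug/mL to 150 ug/mL.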

Compound 4, solubility: 59 ug/mL
Beside the measured number, compound 4's estimate is 1.5-fold (0.17 log units) below it, within the range that was stated.
By their numbers in this assay, from the lowest: compounds 3, 4 and 2 (each within the scatter of the next). At a limit, above all of these: compound 1.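

In this assay, 2-chlorophenyl on this aromatic carbon, next to the ring nitrogen, leaves the number within the scatter of both neighbours: a 1.6-fold higher number from compound 3 to compound 4 (0.20 log units; within the scatter), and a 1.2-fold lower number from compound 2 to compound 4 (0.07 log units; within the scatter). So the three pendant rings, one of which carries a hydrogen-bond donor and acceptor while 2-chlorophenyl carries neither, cannot be told apart in this assay. Nothing measured here gives a cause for these steps.

Open, on these data alone, is whether an amine or a sulfonic acid on the pendant ring would stay with these three compounds or part from them. Compound 1, the only carboxylic acid shown, gives > 1000 ug/mL, a limit and not a number.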